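The compounds below may be only part of what the source reports. "The series", "measured", "known", "first", "only" and "open" are said of these compounds alone.

Of the compounds shown here, two built on one shared core have been tested in an assay on S100 cells for inhibition of Polyunsaturated fatty acid 5-lipoxygenase (Homo sapiens), read by HPLC, with stated times of 15 min and 10 min; a higher number here means a weaker inhibitor, a lower number a stronger inhibitor. Compound 1 `Cc1ccc2nc(-c3cccc(Oc4ccccc4)c3)c(NC3CCCCC3)n2c1` gives 50 nM. Compound 2 `Cc1ccc2nc(-c3ccncc3)c(NC3CCCCC3)n2c1` gives 7700 nM, the higher of the two numbers, and the gap to compound 1 lies beyond the usual scatter. Compound 3 `COc1ccc(-c2nc3ccc(C)cn3c2NC2CCCCC2)cc1` is not yet measured; it differs from compound 2 by 4-methoxyphenyl in place of pyridin-4-yl on an aromatic carbon. Compound 1 carries a different group at that same place and gives 50 nM, which supports expecting a lower number. The step of a 26-fold lower number from compound 2 to compound 3 (1.41 log units; beyond the scatter) is expected to be large, toward a stronger inhibitor. Compound 3 is estimated at 300 nM, ranging from 60 nM to 1500 nM.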

Compound 3, half-maximal inhibitory concentration: 500 nM
For compound 3 the middle estimate is 1.7-fold (0.22 log units) below the measured one; the range from low to high includes it.
By their numbers in this assay, from the lowest: compound 1; then compound 3; then compound 2.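

In this assay, the step of a 15-fold lower number from compound 2 to compound 3 (1.19 log units; beyond the scatter) shows that this aromatic carbon responds strongly even when one single six-membered aromatic ring, pyridin-4-yl, gives way to another, 4-methoxyphenyl. The group of compound 1 still gives the lower number, with compound 1 at 50 nM and compound 3 at 500 nM. Nothing available here explains the step. As far as these compounds go, the change replaces the ring nitrogen and adds methoxy together, so their separate contributions remain open. A plain phenyl ring, or a phenyl ring carrying chlorine instead of methoxy, could help separate them.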